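A few compounds are considered here, and "the series" means these few. Any claim that something is new, unique, unknown or untested is made for them only; others in the source may bear on it.

Compound 1 `O=c1cc(Cn2cc(CCCCl)nn2)c2ccc(O)cc2o1`: in a functional assay on CFPAC-1 cells (Homo sapiens) for inhibition, read by MTT assay, with a stated time of 72 h (on this read-out higher numbers stand for weaker inhibition and lower numbers for stronger inhibition), 75800 nM.
Compound 2 `CC(O)c1cn(Cc2cc(=O)oc3cc(O)ccc23)nn1`: in this assay, a limit only, > 100000 nM.
Compound 3 `O=c1cc(Cn2cc(CCCO)nn2)c2ccc(O)cc2o1`: in this assay, a limit only, > 100000 nM.

Compound 3 stands at the limit of > 100000 nM in this assay, at which 2 of the 3 values shown sit, so its number is not known, only that limit. Compound 4 `CC(C)(C)c1cn(Cc2cc(=O)oc3cc(O)ccc23)nn1` differs from it by tert-butyl in place of 3-hydroxypropyl on an aromatic carbon. Among the compounds with values here, two measured steps touch this position: an at least 1.3-fold higher number from compound 1 to compound 3 (0.12 log units; that floor lies within the scatter), and a step that the two limits leave unreadable from compound 2 to compound 3. Neither gives a readable size, and nothing measured bears directly on a tert-butyl here. An estimate that rests on these limits can only expect compound 4 to stay near the weak end, with a step of an at least 1.1-fold lower number from compound 3 to compound 4 (0.04 log units; that floor lies within the scatter). Compound 4 is therefore estimated at 90000 nM, with a range from 30000 nM to 200000 nM.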

Compound 4, half-maximal inhibitory concentration: > 100000 nM
Compound 4 gave a limit, no number; the forecaster's own chance of this, stated with the estimate: 60%; middle value at least 1.1-fold (0.04 log units) from the limit.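

Compound 4 replaces the hydroxy-bearing chains with tert-butyl, which has 0 hydrogen-bond donors, yet it too gives only a limit, like compound 2 and compound 3: the limit of > 100000 nM in this assay, at which 3 of the 4 values shown sit.

Within the data shown here, the only readable step is an at least 1.3-fold higher number from compound 1 to compound 4 (0.12 log units; that floor lies within the scatter). Going by these compounds, the steps among the three compounds at the limit cannot be read, so the order of compound 2, compound 3 and compound 4 stays unknown.

On these data alone, whether an amine, a carboxylic acid or a longer chain ending in chloro on this aromatic carbon would give a measurable number in this assay stays open.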